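A few compounds are considered here, and "the series" means these few. Any claim that something is new, unique, unknown or untested is made for them only; others in the source may bear on it.

In a functional assay on MDA-MB-231 cells (Homo sapiens) for antiproliferative activity, read by MTT assay, with a stated time of 72 h (on this read-out higher numbers stand for weaker inhibition and lower numbers for stronger inhibition), compound 1 (`O=S1(=O)C=Cc2cccc(Nc3ccc(Cl)cc3)c21`) gives 1210 nM and stands lowest of the two numbers at hand. Compound 2 (`Cc1cc(C)cc(Nc2cccc3c2S(=O)(=O)C=C3)c1`) gives 3120 nM as the higher number, a gap beyond the usual scatter. Compound 3 (`COc1ccc(Nc2cccc3c2S(=O)(=O)C=C3)cc1`) differs from compound 1 by having methoxy in place of chloro on an aromatic carbon. Among the measured compounds shown here, no measured step shows this change, so in this assay only a small rise in the number is expected, possibly none beyond the scatter. The expected move is a 1.5-fold higher number from compound 1 to compound 3 (0.17 log units; within the scatter) in size. For compound 3 the estimated value is 1800 nM (expected range 700 nM to 4500 nM).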

Compound 3, half-maximal inhibitory concentration: 1040 nM
Compound 3: the middle estimate sits 1.7-fold (0.24 log units) above what was measured, and the stated range covers the measured number.
By their numbers in this assay, from the lowest: compounds 3 and 1 (each within the scatter of the next); then compound 2.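

In this assay, methoxy in place of chloro on an aromatic carbon, para to a large group, gives a small step (a 1.2-fold lower number from compound 1 to compound 3 (0.07 log units; within the scatter)). At this position, then, a group of two heavy atoms with one hydrogen-bond acceptor replaces a single chlorine without a change beyond the scatter. Nothing measured here accounts for this result.

From the compounds shown here alone, whether an amine or a carboxylic acid at this position would stay within the scatter remains open. So does whether a longer chain, such as ethoxy, would do so.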